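The compounds below may be only part of what the source reports. "The series", "measured", "known", "first", "only" and "open" are said of these compounds alone.

Measured so far in a functional assay on HeLa cells (Homo sapiens) for antiproliferative activity, read by MTT assay, with a stated time of 72 h; on this read-out higher numbers stand for weaker inhibition and lower numbers for stronger inhibition:
- Compound 1 `COc1cc(-c2nccn2S(=O)(=O)c2ccccc2)cc(OC)c1OC`: > 100000 nM
- Compound 2 `COc1ccc(OC(=O)c2cc(OC)c(OC)c(OC)c2)cc1[N+](=O)[O-]`: > 100000 nM

Both entries are limits of the assay, not numbers, so they cannot be placed in any order. Compound 2 stands at the limit of > 100000 nM. Going by the values given here, the whole record so far is the limit of > 100000 nM in this assay, at which 2 of the 2 values shown sit, so no measured compound yet shows a number to compare against.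

Compound 3 `COc1ccc(OC(=O)c2cc(OC)c(OC)c(OC)c2)cc1N` keeps the structure of compound 2 except at one place: amino in place of nitro on an aromatic carbon. Amino replaces nitro on an aromatic carbon, ortho to a methoxy group and meta to a large group.

Among the compounds with values here, no measured step shows what this exchange does, so any expectation here is loosely held. A shift toward stronger inhibition in this assay, beyond the usual scatter, is expected, although another reading at the limit remains quite possible. The estimated change is an at least 12-fold lower number from compound 2 to compound 3 (1.09 log units; beyond the scatter). For compound 3 the estimated value is 8000 nM, with an expected range of 400 nM to 100000 nM.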

Compound 3, half-maximal inhibitory concentration: > 100000 nM
Compound 3: a limit, no number (the forecaster's own chance of this, stated with the estimate: 35%); middle value at least 12-fold (1.09 log units) from the limit.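

In this assay compound 3 gives a limit of the assay and not a number, as compound 2 does, so putting amino in place of nitro yields no readable step between them: the limit of > 100000 nM in this assay, at which 3 of the 3 values shown sit. From the compounds shown here alone, what remains open is how strongly, if at all, any of these three compounds inhibits, and so what this exchange actually does.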